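This account rests on a few compounds, and the source may have more. Where it says the series, first, only, none or still open, it means among the compounds named here.

Measured compounds in an assay on isolated protein for agonist activity at melatonin receptor type 1C (Xenopus laevis), read by spectrophotometry; a lower number here means a smaller maximal response, a higher number a larger maximal response:
Compound 1, `CCC(=O)NCc1ccc(F)c(OC)c1`, gives 86%.
Compound 2, `CCCC(=O)NCc1ccc(F)c(OC)c1`, gives 75%.
Compound 3, `CCC(=O)NCCCc1ccc(OC)c(F)c1`, gives 78%.

Compound 2 differs from compound 1 by methyl in place of hydrogen on a saturated chain carbon, two bonds along the chain from a carbonyl carbon. This step is a number 11 percentage points lower from compound 1 to compound 2 (beyond the scatter). Compound 3 carries a different core; the difference between the two cores is not broken down here. Compound 3 and compound 2 lie within the scatter of each other, as do compound 3 and compound 1.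

Compound 4, `CCCC(=O)NCCCc1ccc(OC)c(F)c1`, is not yet measured. It differs from compound 3 by methyl in place of hydrogen on a saturated chain carbon, two bonds along the chain from a carbonyl carbon, the same change as from compound 1 to compound 2, at the same place. Within the data shown here, on the one measured instance of this change, the step from compound 3 to compound 4 in this assay is expected to be a number 10 percentage points lower from compound 3 to compound 4 (within the scatter), resting on a number 11 percentage points lower from compound 1 to compound 2 (beyond the scatter). Compound 4 is accordingly estimated at 68% in this assay.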

Compound 4, largest response reached (reported as efficacy), in percent of the reference or control that the assay uses: 73%
Estimate against measurement, compound 4: 5 percentage points below; the measured number falls inside the stated range.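

In this assay, methyl in place of hydrogen on the saturated chain carbon two bonds along from the carbonyl carbon gives a number 5 percentage points lower from compound 3 to compound 4 (within the scatter). Set beside the earlier step, the change carries from one core to the other without a difference that can be told from the scatter: the same change on two cores in this assay, a number 11 percentage points lower (beyond the scatter) from compound 1 to compound 2 and a number 5 percentage points lower (within the scatter) from compound 3 to compound 4, 6 percentage points apart, within the scatter of two such steps. Among these compounds, this rests on only two cores and does not fix a common size for the step, nor show that it would hold on any other core.

Still open, from the compounds shown here alone, is how a longer chain, a branched chain or a cyclopropyl group on the carbonyl would read. Going by these compounds, an amine or a carboxylic acid at this chain end is equally open.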